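From Chloro to Phenyl on a Shared Core

The compounds below may be only part of what the source reports. "The series", "measured", "known", "first", "only" and "open" are said of these compounds alone.

Measured in a functional assay on HeLa cells (Homo sapiens), read by colorimetric assay, with a stated time of 48 h; on this read-out lower numbers stand for stronger inhibition and higher numbers for weaker inhibition:
- Compound 1 `OC[C@@H](O)[C@H]1O[C@@H](n2cnc3c(Cl)ncnc32)[C@H](O)[C@@H]1O`: > 100000 nM
- Compound 2 `OC[C@@H](O)[C@H]1O[C@@H](n2cnc3c(Cl)nc(Cl)nc32)[C@H](O)[C@@H]1O`: 47100 nM
- Compound 3 `CNc1nc(Cl)nc2c1ncn2[C@@H]1O[C@H]([C@H](O)CO)[C@@H](O)[C@H]1O`: > 100000 nM

Compound 1 gives no number, only a limit of the assay, > 100000 nM. It stands on (the limit of > 100000 nM in this assay, at which 2 of the 3 values shown sit). Compound 3 likewise reaches only a limit, > 100000 nM. The next compound is compound 4 `OC[C@@H](O)[C@H]1O[C@@H](n2cnc3c(-c4ccccc4)ncnc32)[C@H](O)[C@@H]1O`, which carries phenyl in place of chloro on an aromatic carbon.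

Among the compounds with values here, no measured step makes this exact exchange, so the guidance is indirect. Adding a chloro in place of hydrogen on an aromatic carbon gave an at least 2.1-fold lower number from compound 1 to compound 2 (0.32 log units; beyond the scatter). Exchanging a chloro for methylamino gave an at least 2.1-fold higher number from compound 2 to compound 3 (0.32 log units; beyond the scatter). This second step also removes a chloro, but the group that enters is not phenyl. On these data alone, both steps are beyond the scatter, yet each rests on a limit, so their true sizes remain open.

Within the data shown here, the expectation therefore leans on compound 2, whose 47100 nM is the only number measured in this assay. A modest move to a lower number is expected, and compound 4 may well stay at the limit. The expected step is an at least 1.6-fold lower number from compound 1 to compound 4 (0.22 log units; that floor lies within the scatter). For compound 4 the estimate is 60000 nM, with an expected range from 15000 nM to 100000 nM.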

Compound 4, half-maximal inhibitory concentration: > 100000 nM
Compound 4 ended at the assay's limit; the forecaster's own chance of this, stated with the estimate: 55%; at least 1.6-fold (0.22 log units) between middle value and limit.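

In this assay compound 4 gives > 100000 nM, which is a limit of the assay and not a number. Compound 1 also stands at a limit, so no step from compound 1 to compound 4 can be read: the limit of > 100000 nM in this assay, at which 3 of the 4 values shown sit.

The compounds shown leave open whether phenyl in place of chloro changes inhibition at all.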